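Swapping the amide aryl group on a triazole amide

The compounds below may be only part of what the source reports. "The series", "measured", "known", "first", "only" and "open" are said of these compounds alone.

Compound 1 `Nc1nccc2cc(CNC(=O)Cn3cnc(C(=O)NC4CCCCC4)n3)ccc12` gives > 100000 nM in an assay for inhibition of histone-lysine N-methyltransferase, H3 lysine-79 specific (Homo sapiens), read by luminescence, with a stated time of 1 h (a lower number here means a stronger inhibitor, a higher number a weaker inhibitor), which is a limit of the assay rather than a number; this is the limit of > 100000 nM in this assay, at which 1 of the 3 values shown sits. For the measured compounds named here, compound 2 `Cc1ccc(NC(=O)c2ncn(CC(=O)NCCn3ccc4c(N)ncnc43)n2)cc1C` gives 10900 nM, the lowest of the two numbers, while compound 3 `Cc1ccc(NC(=O)c2ncn(CC(=O)NCCn3cnc4[nH]ccc4c3=O)n2)cc1C` gives 138000 nM, and the only measured step is a 13-fold higher number from compound 2 to compound 3 (1.10 log units; beyond the scatter), a change at the far end of the chain. Compound 4 `CC(C)(C)c1ccc(NC(=O)c2ncn(CC(=O)NCCn3ccc4c(N)ncnc43)n2)cc1` differs from compound 2 by 4-(tert-butyl)phenyl in place of 3,4-dimethylphenyl on an amide-type nitrogen. Going by the values given here, no measured step touches this amide aryl group, so nothing here points in either direction, and a step no larger than the scatter is expected, a 1.1-fold lower number from compound 2 to compound 4 (0.04 log units; within the scatter). Compound 4 is therefore estimated at 10000 nM, between 3000 nM and 40000 nM.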

Compound 4, half-maximal inhibitory concentration: 1000 nM
Estimate against measurement, compound 4: 10-fold (1.00 log units) above, and the stated range ends above it.
By their numbers in this assay, from the lowest: compound 4; then compound 2; then compound 3.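

For the compounds shown here, the amide aryl group, which no earlier step had touched, proves to matter in this assay: 4-(tert-butyl)phenyl in place of 3,4-dimethylphenyl on an amide-type nitrogen gives a large step beyond the scatter (an 11-fold lower number from compound 2 to compound 4 (1.04 log units; beyond the scatter)). The number moves the opposite way from the change at the far end of the chain (a 13-fold higher number from compound 2 to compound 3 (1.10 log units; beyond the scatter)). Nothing measured here gives a cause for this step.

The compounds shown leave open whether an isopropyl or trifluoromethyl group could stand in for the tert-butyl group. From the compounds shown here alone, it also remains open whether the same swap would carry over to the far end of compound 3.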